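The compounds below may be only part of what the source reports. "The series", "measured", "known", "first", "only" and "open" are said of these compounds alone.

Of the compounds shown here, three with a shared core have been tested in a functional assay on CCRF-CEM cells (Homo sapiens) for antiproliferative activity; a higher number here means a weaker inhibitor, a lower number a stronger inhibitor. Compound 2 `COc1cc(C(=O)c2sc(-c3ccc([N+](=O)[O-])cc3)cc2N)cc(OC)c1OC`, which carries a 4-nitrophenyl group, gives 99 nM. Its chloro counterpart is compound 3 `COc1cc(C(=O)c2sc(-c3ccc(Cl)cc3)cc2N)cc(OC)c1OC`, and compound 3 gives 70 nM. The step between them is a 1.4-fold lower number from compound 2 to compound 3 (0.15 log units; within the scatter), so the two stand level. Compound 1 `COc1cc(C(=O)c2sc(-c3ccc(-c4ccccc4)cc3)cc2N)cc(OC)c1OC` gives > 10000 nM, which is a limit of the assay and not a number.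

Compound 4 `COc1cc(C(=O)c2sc(-c3ccccc3)cc2N)cc(OC)c1OC` has not yet been measured. It has hydrogen in place of nitro on an aromatic carbon, para to a large group: hydrogen in place of nitro on an aromatic carbon. Among the compounds with values here, no measured step makes this exact change, so the nearest guides are the other swaps at that carbon. Exchanging nitro for chloro changed little, but the large steps all involve phenyl: an at least 100-fold lower number from compound 1 to compound 2 (2.00 log units; beyond the scatter) and an at least 140-fold lower number from compound 1 to compound 3 (2.15 log units; beyond the scatter). Hydrogen brings no ring and no heavy atom, so compound 4 is expected to stay with compound 2 rather than with compound 1, though with real uncertainty. The expected step is a 1.2-fold higher number from compound 2 to compound 4 (0.08 log units; within the scatter), which would not go beyond the scatter. Compound 4 is estimated at 120 nM, within an expected range of 35 nM to 450 nM.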

Compound 4, half-maximal inhibitory concentration: 4.5 nM
Compound 4: middle estimate off by 27-fold (1.43 log units), on the high side; measured number outside the range, below it.
By their numbers in this assay, from the lowest: compound 4; then compounds 3 and 2 (each within the scatter of the next). At a limit, above all of these: compound 1.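

The level pair of compound 2 and compound 3 made this carbon look indifferent to what it carries, but that held only among substituents. In this assay, phenyl with hydrogen at this carbon is clearly the best of the four, with a 22-fold lower number from compound 2 to compound 4 (1.34 log units; beyond the scatter) and a 16-fold lower number from compound 3 to compound 4 (1.19 log units; beyond the scatter), so each of the three groups tried here costs activity and none goes against that pattern. The largest gap, an at least 2200-fold lower number from compound 1 to compound 4 (3.34 log units; beyond the scatter), rests on a limit for compound 1 and not on a number: the limit of > 10000 nM in this assay, at which 1 of the 4 values shown sits.

The compounds shown do not tell whether any group at this carbon can match hydrogen, such as a fluorine atom, a methyl, a methoxy or an amine. They also give no cause for the gap between hydrogen and the groups tried.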